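A few compounds are considered here, and "the series" means these few. Any claim that something is new, unique, unknown or untested is made for them only; others in the source may bear on it.

Compound 1, `Cc1ccc2ncc(S(=O)(=O)c3ccc(Cl)c(Cl)c3)c(N3CCC(C)CC3)c2c1`, gives 82% in an assay on isolated protein for displacement of a labelled ligand from metabotropic glutamate receptor 5 (Homo sapiens), with a stated time of 60 min, tested at 1 uM; on this read-out higher numbers stand for more inhibition at the one concentration tested (going by the name of the read-out) and lower numbers for less inhibition.
Compound 2, `Cc1ccc2ncc(S(=O)(=O)c3cc(F)cc(F)c3)c(N3CCC(C)CC3)c2c1`, gives 72% in this assay.
Compound 3, `Cc1ccc(S(=O)(=O)c2cnc3ccc(C)cc3c2N2CCC(C)CC2)cc1`, gives 82% in this assay.

Compound 2 has the lowest of the three numbers, but this says little: the step of a number 10 percentage points lower from compound 1 to compound 2 (within the scatter) and the step of a number 10 percentage points higher from compound 2 to compound 3 (within the scatter) both lie within the scatter of the measurement, as does the step of no change at the digits printed from compound 1 to compound 3 (within the scatter). All three compounds therefore sit at about the same level in this assay.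

Compound 4, `CC1CCN(c2c(S(=O)(=O)c3cc(F)cc(F)c3)cnc3ccc(Cl)cc23)CC1`, has not been measured. It differs from compound 2 in one place: chloro in place of methyl on an aromatic carbon. The three measured steps all exchange the aryl group on the sulfonyl sulfur and leave the rest of the molecule untouched, so none of them probes the position that changes here. Going by the values given here, the only guide is that three compounds sharing this core all give similar numbers in this assay. On that basis the step from compound 2 to compound 4 is expected to be no change at the digits printed from compound 2 to compound 4 (within the scatter), that is nothing beyond the scatter. Compound 4 is accordingly estimated to give 72% in this assay, with a range from 55% to 88%.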

Compound 4, a percentage reported as inhibition, at one concentration (the size of the read-out at that concentration, not a potency): 93%
For compound 4 the middle estimate is 21 percentage points below the measured one; measured number above the stated range.
By their numbers in this assay, from the lowest: compounds 2, 1 and 3 (each within the scatter of the next); then compound 4.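

The aromatic carbon that carries this change, on the six-membered ring of carbon only within the fused system, had held methyl in every earlier compound, so the earlier results could say nothing about it. In this assay, chloro in place of methyl gives a number 21 percentage points higher from compound 2 to compound 4 (beyond the scatter), the only step among these compounds that lies beyond the scatter. Exchanging the aryl group on the sulfonyl sulfur has so far left the number within the scatter, whereas this single-atom exchange on the shared core does not, and no measurement bears on why the number moves.

From the compounds shown here alone, this reading rests on one pair with 3,5-difluorophenyl on the sulfonyl sulfur, so it remains open whether chloro gives a similar step with 3,4-dichlorophenyl or 4-methylphenyl there, and what a methoxy group, a nitrile or an amine would give at the same carbon. Going by these compounds, the read-out also comes from one concentration and shows the size of the inhibition there rather than a potency, so how far compound 2 and compound 4 differ in potency remains open too.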